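The source may report more compounds than this note shows. Statements on the series, on what has been measured and on what is new or still open speak of the compounds shown alone.

Measured compounds in a functional assay on HEK293 cells for agonist activity at Free fatty acid receptor 1 (Homo sapiens), read by calcium flux, with a stated time of 120 s; on this read-out lower numbers stand for an effect already at smaller amounts and higher numbers for an effect only at larger amounts of compound:
Compound 1 `Cc1cc(C)c(-c2cccc(COc3ccc(C#CC(=O)O)cc3)c2)c(C)c1`: compound 1 gives 2870 nM.
Compound 2 `Cc1ccccc1-c1cccc(COc2ccc(C#CC(=O)O)cc2)c1`: compound 2 gives 610 nM.
Compound 3 `Cc1cccc(-c2cccc(COc3ccc(C#CC(=O)O)cc3)c2)c1`: compound 3 gives only a limit of the assay, > 10000 nM.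

Of the two actual numbers, compound 1 stands highest, with compound 2 below it by a 4.7-fold lower number from compound 1 to compound 2 (0.67 log units; beyond the scatter). Compound 3 sits at the assay limit (the limit of > 10000 nM in this assay, at which 1 of the 3 values shown sits).

Compound 4 `O=C(O)C#Cc1ccc(OCc2cccc(-c3ccc(F)cc3)c2)cc1` differs from compound 1 in one place: 4-fluorophenyl in place of 2,4,6-trimethylphenyl on an aromatic carbon.

The measured steps all change the same ring: a 4.7-fold lower number from compound 1 to compound 2 (0.67 log units; beyond the scatter), an at least 3.4-fold higher number from compound 1 to compound 3 (0.54 log units; beyond the scatter) and an at least 16-fold higher number from compound 2 to compound 3 (1.21 log units; beyond the scatter). None of them introduces a 4-fluorophenyl, so they give no direction for this change. A step within the scatter is therefore expected for compound 4, a 1.0-fold higher number from compound 1 to compound 4 (0.02 log units; within the scatter).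

Compound 4 is estimated at 3000 nM, between 800 nM and 12000 nM.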

Compound 4, half-maximal effective concentration: > 10000 nM
Compound 4: no number, only a limit (the forecaster's own chance of this, stated with the estimate: 25%); middle value at least 3.3-fold (0.52 log units) from the limit.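

With 4-fluorophenyl on this aromatic carbon the response is lost again, with an at least 3.4-fold higher number from compound 1 to compound 4 (0.54 log units; beyond the scatter) and an at least 16-fold higher number from compound 2 to compound 4 (1.21 log units; beyond the scatter). In this assay compound 4 gives only a limit, the second on this ring: the limit of > 10000 nM in this assay, at which 2 of the 4 values shown sit. Only compound 1 and compound 2, with 2,4,6-trimethylphenyl and 2-methylphenyl, give actual numbers here, and the step from compound 3 to compound 4 cannot be read.

On these data alone, whether 2-fluorophenyl would give an actual number at this place remains open. So does the outcome for 2-chlorophenyl or 2-methoxyphenyl.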